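Adding a methoxycarbonyl group to compound 2

The compounds below may be only part of what the source reports. "The series", "measured", "known", "first", "only" and "open" are said of these compounds alone.

Compound 1 `CCCCCCCCn1nc(-c2cccnc2)c2ccccc2c1=O`: 21900 nM
Compound 2 `O=c1c2ccccc2c(-c2cccnc2)nn1Cc1ccccc1`: 2450 nM

In a functional assay (trachea) with Cavia porcellus as the target (on this read-out higher numbers stand for weaker inhibition and lower numbers for stronger inhibition), compound 2 gives the lower of the two numbers, 2450 nM, which makes it the stronger inhibitor of the pair. The next compound, compound 3 `COC(=O)c1ccc(Cn2nc(-c3cccnc3)c3ccccc3c2=O)cc1`, keeps the phenyl of compound 2 and carries one change on it: methoxycarbonyl in place of hydrogen on an aromatic carbon. Going by the values given here, only one measured step bears on this, and only indirectly. Phenyl in place of heptyl gave an 8.9-fold lower number from compound 1 to compound 2 (0.95 log units; beyond the scatter), a modest step beyond the scatter that shows this assay can respond to a change in this part of compound 2. Among the compounds with values here, no measured step adds a group to the phenyl, so neither size nor direction can be carried over, and no step beyond the scatter is expected. The estimate is an expected 1.2-fold lower number from compound 2 to compound 3 (0.09 log units; within the scatter). Compound 3 is expected to read 2000 nM, with an estimated range of 500 nM to 8000 nM.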

Compound 3, half-maximal inhibitory concentration: 5890 nM
The estimate for compound 3 lay 2.9-fold (0.47 log units) below the measured number; low and high end bracket the measured number.
By their numbers in this assay, from the lowest: compound 2; then compound 3; then compound 1.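

Going by these compounds alone, until now, the only change read in this part of the molecule had replaced the whole heptyl with phenyl; compound 3 gives the first reading of a substituent on the phenyl itself. In this assay the methoxycarbonyl group, para to a large group, gives a 2.4-fold higher number from compound 2 to compound 3 (0.38 log units; beyond the scatter) and so moves the read-out toward weaker inhibition, modestly but beyond the scatter. The phenyl therefore does not accept this addition without a measurable change in the read-out, and nothing available explains the loss.

With only one substituent shown, it remains open whether the loss belongs to methoxycarbonyl or to substitution at this carbon generally. A carboxylic acid, an amine or a single chlorine atom in the same place could separate these two readings.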